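The source may hold more compounds than are shown below. What is called first, only, known or untested is meant among the compounds shown, and "the series" means these compounds.

Measured in an ADME assay on MRC5 cells (Homo sapiens) for inhibition, with a stated time of 72 h; a higher number here means that more compound is needed for the effect, a lower number that less compound is needed:
- Compound 1 `COc1cccc(OC)c1C(=O)Nc1c[nH]nc1C(=O)N[C@H]1CC[C@H](OC)CC1`: 31000 nM
- Compound 2 `COc1cccc(OC)c1C(=O)Nc1c[nH]nc1C(=O)NCc1ccccn1`: > 50000 nM

Compound 2 stands at the limit of > 50000 nM in this assay, at which 1 of the 2 values shown sits, which is a limit and not a number. Compound 3 `COc1cccc(OC)c1C(=O)Nc1c[nH]nc1C(=O)NCc1ccccc1` has phenyl in place of pyridin-2-yl on a saturated chain carbon bound to an amide-type nitrogen. Among the measured compounds shown here, the one measured step, an at least 1.6-fold higher number from compound 1 to compound 2 (0.20 log units; that floor lies within the scatter), changes a group on the same amide-type nitrogen, but it gives only a floor and no true size. No step beyond the scatter is therefore expected. The estimated change is an at least 1.1-fold lower number from compound 2 to compound 3 (0.04 log units; that floor lies within the scatter). For compound 3, the expected value in this assay is 45000 nM, with an estimated range of 20000 nM to 80000 nM.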

Compound 3, half-maximal effective concentration: 50000 nM
The estimate for compound 3 lay 1.1-fold (0.05 log units) below the measured number; measured number inside the range.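

Benzyl in place of 4-methoxycyclohexyl on the amide-type nitrogen gives a 1.6-fold higher number from compound 1 to compound 3 (0.21 log units; within the scatter) in this assay, a true size that compound 2 could not provide. Phenyl in place of pyridin-2-yl on the saturated chain carbon gives a number no higher from compound 2 to compound 3 (the limit leaves the size open). The size of this step cannot be read, because compound 2 carries a limit and not a number: the limit of > 50000 nM in this assay, at which 1 of the 3 values shown sits.

The compounds shown leave open how far pyridin-2-yl and phenyl truly differ here. They also leave open whether an amine or a carboxylic acid on this chain would move the number beyond the scatter.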